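Removing the pyridin-4-yl group from compound 3

The source may report more compounds than this note shows. Statements on the series, on what has been measured and on what is new or still open speak of the compounds shown alone.

Compound 3 `COc1cc2ncnc(-n3nc(-c4ccncc4)nc3N)c2cc1OC` gives 5000 nM in an assay on MCF7 cells for inhibition of Serine-protein kinase ATM (Homo sapiens), read by immunofluorescence, with a stated time of 1 h (on this read-out lower numbers stand for stronger inhibition and higher numbers for weaker inhibition), the lowest of the two numbers in hand. Compound 2 `COc1cc2ncnc(-n3nc(-c4ccccn4)nc3N)c2cc1[N+](=O)[O-]` sits at 31100 nM, a gap beyond the scatter. For compound 1 `Nc1cc2c(-n3nc(-c4ccccn4)nc3N)ncnc2cc1Cl` only a limit is known, > 40000 nM, which is the limit of > 40000 nM in this assay, at which 1 of the 3 values shown sits. Going by the values given here, no pair of measured compounds differs in a single place, so no measured step is available to lean on. Compound 4 `COc1cc2ncnc(-n3nc(N)nc3N)c2cc1OC` differs from compound 3 by amino in place of pyridin-4-yl on an aromatic carbon. The step of a 5.0-fold higher number from compound 3 to compound 4 (0.70 log units; beyond the scatter) is expected to run toward weaker inhibition, beyond the scatter. Compound 4 is accordingly estimated at about 25000 nM, with a range from 7000 nM to 40000 nM, and a real chance that this assay reports only a limit.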

Compound 4, half-maximal inhibitory concentration: > 40000 nM
Compound 4 was reported as a limit (the forecaster's own chance of this, stated with the estimate: 40%); middle value at least 1.6-fold (0.20 log units) from the limit.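

Going by these compounds alone, this gives the first single-place comparison. On the aromatic carbon between two ring nitrogen atoms, amino in place of pyridin-4-yl costs inhibition in this assay, with an at least 8.0-fold higher number from compound 3 to compound 4 (0.90 log units; beyond the scatter). The value of compound 4 is a limit, so this step gives only a lower bound, and the true size stays unknown: the limit of > 40000 nM in this assay, at which 2 of the 4 values shown sit.

On these data alone, whether the loss follows the ring as a whole or its nitrogen stays open; a phenyl ring or a methyl group on this carbon would separate the two. Compounds 1 and 2 carry pyridin-2-yl but differ from compound 3 elsewhere too, so the position of the pyridine nitrogen cannot be read.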